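The source may hold more compounds than are shown below. What is called first, only, known or untested is meant among the compounds shown, and "the series" means these compounds.

Measured compounds:
Compound 1, `CCN(c1nc(Cl)nc(N[C@@H](C)c2ccccc2)n1)C(C)C`, gives 537 nM in an ADME assay on the whole organism for inhibition, with Oryza sativa as the target, with a stated time of 4 days; a lower number here means a stronger inhibitor, a higher number a weaker inhibitor.
Compound 2, `C[C@@H](Nc1nc(Cl)nc(NC(C)(C)C)n1)c1ccccc1`, gives 9330 nM in this assay.

Compound 2 stands at the higher of the two numbers: its value is well beyond the scatter from that of compound 1, so compound 2 is the weaker inhibitor of the pair by a clear margin.

Compound 3, `CC(C)Nc1nc(Cl)nc(N[C@H](C)c2ccccc2)n1`, has not yet been measured. It differs from compound 2 in one place: hydrogen in place of methyl on a saturated chain carbon bound to a nitrogen on an aromatic ring and two saturated chain carbons. No measured pair shows this exact change, so the size of the step is not fixed by the data shown. On the evidence of compound 1 and its value of 537 nM, the smaller substituent pattern on the shared core sits at a lower number, and compound 3 is expected to move in that direction. The step from compound 2 to compound 3 is estimated at a 3.1-fold lower number from compound 2 to compound 3 (0.49 log units; beyond the scatter). Compound 3 is therefore expected to give about 3000 nM, within a range of 1000 nM to 9000 nM.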

Compound 3, half-maximal inhibitory concentration: 5370 nM
Compound 3: middle estimate off by 1.8-fold (0.25 log units), on the low side, within the range that was stated.
By their numbers in this assay, from the lowest: compound 1; then compounds 3 and 2 (each within the scatter of the next).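

Going by these compounds alone, compounds 2 and 3 differ only in tert-butyl against isopropyl, and in this assay this pair gives the first direct reading of that change, with a 1.7-fold lower number from compound 2 to compound 3 (0.24 log units; within the scatter). Hydrogen in place of methyl, on a saturated chain carbon bound to a nitrogen on an aromatic ring and two saturated chain carbons, therefore does not separate the two compounds in this assay, and this single pair is all that shows it. No measurement is at hand that would account for this result.
As far as these compounds go, whether a different group at this place, such as a cyclopropyl ring, a longer chain or a plain amine, would give a number beyond the scatter remains open. Also open is whether the same change would read alike on a core carrying something other than the chlorine of these compounds.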